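The source may report more compounds than this note shows. Statements on the series, on what has been measured and on what is new or still open speak of the compounds shown alone.

Of the compounds shown here, three have been tested so far in an ADME assay on BaF3 cells (Mus musculus) for antiproliferative activity, read by CCK-8 assay, with a stated time of 72 h; a lower number here means a stronger inhibitor of growth, a higher number a weaker inhibitor of growth. Compound 1 `O=C(CCSc1ccc2c(/C=C/c3ccccn3)n[nH]c2c1)Nc1ccc(F)c(C(F)(F)F)c1` gives 610 nM, and compound 2 `O=C(NCCSc1ccc2c(/C=C/c3ccccn3)n[nH]c2c1)c1cccc(C(F)(F)F)c1` gives 1500 nM. Compound 3 `CN1CCN(Cc2ccc(NC(=O)CCSc3ccc4c(-c5ccccc5)n[nH]c4c3)cc2C(F)(F)F)CC1` gives 600 nM. This puts compound 3 level with compound 1, since their two numbers lie within the scatter of repeated measurements, while the number for compound 2 is higher by more than that scatter.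

The next molecule, compound 4 `Cc1ccc(-c2n[nH]c3cc(SCCC(=O)Nc4ccc(CN5CCN(C)CC5)c(C(F)(F)F)c4)ccc23)cn1`, changes compound 3 in one place: 6-methylpyridin-3-yl in place of phenyl on an aromatic carbon. The phenyl ring, made of carbon only, gives way to a six-membered aromatic ring with 1 hetero atom, and the rest of the molecule stays the same.

Going by the values given here, no two measured compounds differ in only one place, so nothing here shows directly what such a swap does in this assay. Among the compounds with values here, the only firm anchor is compound 3 at 600 nM, and with so little evidence, no step beyond the scatter is expected in either direction. The expected step is a 1.3-fold lower number from compound 3 to compound 4 (0.12 log units; within the scatter), a small one. For compound 4 the estimated value is 450 nM, with an expected range from 130 nM to 1500 nM.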

Compound 4, concentration for 50% growth inhibition: 1180 nM
Beside the measured number, compound 4's estimate is 2.6-fold (0.42 log units) below it; low and high end bracket the measured number.
By their numbers in this assay, from the lowest: compounds 3, 1, 4 and 2 (each within the scatter of the next, the first and the last beyond it).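

In this assay, going by these compounds alone, this pair gives the first comparison in which only one place differs: a 2.0-fold higher number from compound 3 to compound 4 (0.29 log units; within the scatter). Placing 6-methylpyridin-3-yl instead of phenyl on this aromatic carbon therefore leaves two numbers that repeated measurements could not reliably tell apart, even though the entering ring brings a ring nitrogen, one hydrogen-bond acceptor and one more heavy atom. No measured property of these compounds bears on the result, so the data offer no explanation for it.

The swap changes two features at once, the ring nitrogen and the methyl group, so a plain pyridin-3-yl ring would be needed to look at the ring nitrogen without the methyl group, and a 4-methylphenyl ring to look at the methyl group without the ring nitrogen. On these data alone, whether this position would respond in the same way to a larger change, such as a non-aromatic piperidine ring or a phenyl ring carrying a carboxylic acid, also remains open.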